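Swapping pyrimidin-2-yl for 2-fluorophenyl on two piperazine cores

The source may report more compounds than this note shows. Statements on the series, on what has been measured and on what is new or still open speak of the compounds shown alone.

Measured compounds:
Compound 1, `Cc1ncc([N+](=O)[O-])n1CC(O)CSC(=S)N1CCN(c2ncccn2)CC1`: 2040000 nM
Compound 2, `Cc1ncc([N+](=O)[O-])n1CC(O)CSC(=S)N1CCN(c2ccccc2F)CC1`: 3240000 nM
Compound 3, `Cc1ncc([N+](=O)[O-])n1CC(O)CN1CCN(c2ncccn2)CC1`: 3930000 nM

In a toxicity assay on HeLa cells (Homo sapiens) for cytotoxicity, read by MTT assay, with a stated time of 24 h (on this read-out lower numbers stand for stronger inhibition and higher numbers for weaker inhibition), compound 1 gives 2040000 nM, and compound 2 gives 3240000 nM. The two differ in one place, (2-fluorophenyl in place of pyrimidin-2-yl on an amine nitrogen in a ring), and this change made a 1.6-fold higher number from compound 1 to compound 2 (0.20 log units; within the scatter). Compound 3, with 3930000 nM, shares a core whose difference from that of compound 1 is not broken down here; its value lies within the scatter of both compound 1 and compound 2.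

Compound 4, `Cc1ncc([N+](=O)[O-])n1CC(O)CN1CCN(c2ccccc2F)CC1`, is not yet measured. It carries the same change relative to compound 3, namely (2-fluorophenyl in place of pyrimidin-2-yl on an amine nitrogen in a ring), at a place described in the same words as for compound 1 and compound 2. Since the change from compound 1 to compound 2 stayed within the scatter, compound 4 is expected to lie near compound 3 in this assay, and the estimated step is a 1.4-fold higher number from compound 3 to compound 4 (0.15 log units; within the scatter). Compound 4 is accordingly estimated at 5500000 nM, with a range from 2500000 nM to 12000000 nM.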

Compound 4, half-maximal inhibitory concentration: > 5000000 nM
Compound 4 gave a limit, no number; the forecaster's own chance of this, stated with the estimate: 15%; the middle value is on the limit's open side.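

In this assay compound 4 reads > 5000000 nM, which is a limit of the assay and not a number. Placing 2-fluorophenyl where pyrimidin-2-yl stood on the amine nitrogen in the ring gives an at least 1.2-fold higher number from compound 3 to compound 4 (0.10 log units; that floor lies within the scatter), so the result fits the small step seen on the core of compound 1 but sets only a floor, and the full size of the step on this core stays unknown. The series therefore shows nothing against carrying the change from one core to the other, yet it does not show that the change carries over with the same size: the same change on two cores in this assay, a 1.6-fold higher number (0.20 log units; within the scatter) from compound 1 to compound 2 and an at least 1.2-fold higher number (0.10 log units; that floor lies within the scatter) from compound 3 to compound 4; the limit leaves it open whether they differ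

The compounds shown leave open how other groups on that amine nitrogen, such as an unsubstituted phenyl or a pyridin-2-yl, would read on either core. They also leave open whether a 2-chlorophenyl or a 2-methoxyphenyl in the same place would give a value that could be read on both cores.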